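This account rests on a few compounds, and the source may have more. Where it says the series, first, only, none or still open, it means among the compounds named here.

In a functional assay on MV4-11 cells (Homo sapiens) for antiproliferative activity, read by CellTiter-Glo, with a stated time of 72 h (a lower number here means a stronger inhibitor of growth, a higher number a weaker inhibitor of growth), compound 1 `COCCN[C@H]1CC[C@H](Nc2cc(-c3csc(NCC4CCOCC4)n3)c(Cl)cn2)CC1` gives 170 nM, compound 2 `COCCN[C@H]1CC[C@H](Nc2cc(-c3csc(SCC4CCOCC4)n3)c(Cl)cn2)CC1` gives 340 nM and compound 3 `COCCN[C@H]1CC[C@H](Nc2cc(-c3csc(NCC4CC4)n3)c(Cl)cn2)CC1` gives 740 nM, the highest number of the three. Compound 4 `COCCN[C@H]1CC[C@H](Nc2cc(-c3csc(NCC4CCC4)n3)c(Cl)cn2)CC1` differs from compound 3 in one place, with cyclobutyl in place of cyclopropyl on a saturated chain carbon bound to a nitrogen on an aromatic ring. The most relevant measured change sits at that same place, a 4.4-fold higher number from compound 1 to compound 3 (0.64 log units; beyond the scatter), where oxan-4-yl gives way to cyclopropyl. The step of a 2.2-fold higher number from compound 2 to compound 3 (0.34 log units; beyond the scatter) also alters the sulfanyl link, so it says less, and a 2.0-fold higher number from compound 1 to compound 2 (0.30 log units; within the scatter) does not touch this place at all. Going by the values given here, no measured compound carries cyclobutyl, so the data offer only a weak pointer, from compound 1 with its 170 nM, towards a lower number. The expected step is small, a 1.4-fold lower number from compound 3 to compound 4 (0.15 log units; within the scatter), and is not expected to stand clearly beyond the scatter. For compound 4 the estimated value is 520 nM, with an expected range from 240 nM to 1000 nM.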

Compound 4, concentration for 50% growth inhibition: > 10000 nM
Compound 4: no number, only a limit; the forecaster's own chance of this, stated with the estimate: 1%; middle value at least 19-fold (1.28 log units) from the limit.
By their numbers in this assay, from the lowest: compounds 1 and 2 (each within the scatter of the next); then compound 3. At a limit, above all of these: compound 4.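

In this assay compound 4 gives no number, only a limit: the limit of > 10000 nM in this assay, at which 1 of the 4 values shown sits. The step at this place, cyclobutyl in place of cyclopropyl, is an at least 13-fold higher number from compound 3 to compound 4 (1.13 log units; beyond the scatter), far larger than the modest step seen earlier at the same place, and an at least 58-fold higher number from compound 1 to compound 4 (1.76 log units; beyond the scatter) shows that the group on this saturated chain carbon can decide between a measurable number and the limit, which the earlier compounds had not shown. The step of an at least 29-fold higher number from compound 2 to compound 4 (1.46 log units; beyond the scatter) points the same way, though it also changes the sulfanyl link and so says less about this place alone.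

The compounds shown leave open how cyclopentyl, cyclohexyl or an open chain such as isobutyl would behave at this place. They also leave open whether (cyclobutylmethyl)sulfanyl would give the same result as (cyclobutylmethyl)amino.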